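Thrombopoietin receptor series: removal of an aromatic fluoro

The source may hold more compounds than are shown below. What is called first, only, known or untested is meant among the compounds shown, and "the series" means these compounds.

Measured compounds:
compound 1 `C/C(NNC(=S)N1CCc2cc(C(=O)O)ccc21)=C1/C(=O)N(c2ccc(C)c(C)c2)c2ccccc21`: 72.4%
compound 2 `C/C(NNC(=S)N1CCc2cc(C(=O)O)ccc21)=C1/C(=O)N(c2ccc(C)cc2)c2ccc(F)cc21`: 78.1%

In an assay on BaF3 cells for inhibition of thrombopoietin receptor (Homo sapiens), tested at 150 nM (a higher number here means a stronger effect of the compound at the concentration tested, a lower number a weaker effect), compound 2 gives 78.1% and compound 1 gives 72.4%; the two numbers lie within the scatter of each other, so neither stands apart. Compound 3 `C/C(NNC(=S)N1CCc2cc(C(=O)O)ccc21)=C1/C(=O)N(c2ccc(C)cc2)c2ccccc21` differs from compound 2 by hydrogen in place of fluoro on an aromatic carbon. Among the measured compounds shown here, no measured pair shows this change, so the size of its step is unknown; the expected step in this assay is a number 4.1 percentage points lower from compound 2 to compound 3 (within the scatter), none beyond the scatter. Compound 3 is estimated at 74%, with a range from 60% to 85%.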

Compound 3, a percentage reported as inhibition, at one concentration (the size of the read-out at that concentration, not a potency): 47.8%
Compound 3: middle estimate off by 26.2 percentage points, on the high side, and the stated range ends above it.
By their numbers in this assay, from the lowest: compound 3; then compounds 1 and 2 (each within the scatter of the next).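

In this assay, hydrogen in place of fluoro on this aromatic carbon gives a number 30.3 percentage points lower from compound 2 to compound 3 (beyond the scatter), so the position is not indifferent to this change. Hydrogen in place of methyl on an aromatic carbon, at a different place, gives a number 24.6 percentage points lower from compound 1 to compound 3 (beyond the scatter), and both steps end at compound 3, which carries neither group. No measurement shown bears on why the read-out falls. The compounds shown leave open whether chloro or methoxy on this aromatic carbon would keep the read-out, and what fluoro and the added methyl would give together.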